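The compounds below may be only part of what the source reports. "The series", "measured", "known", "first", "only" and "open" are said of these compounds alone.

In a functional assay on A549 cells (Homo sapiens) for cytotoxicity, read by resazurin assay, with a stated time of 72 h (a higher number here means a weaker inhibitor, a lower number a stronger inhibitor), three compounds with a shared core differ only in the halogen-bearing phenyl group on the ring nitrogen. Compound 1 `N#Cc1cc(-c2ccccc2)n(-c2cccc(Br)c2)c1N` gives 13000 nM, compound 2 `N#Cc1cc(-c2ccccc2)n(-c2ccc(Br)cc2)c1N` gives 4600 nM, and compound 3 `N#Cc1cc(-c2ccccc2)n(-c2ccc(Cl)cc2)c1N` gives 7700 nM. Compound 3 thus stands within the scatter of both other compounds, as shown by a 1.7-fold lower number from compound 1 to compound 3 (0.23 log units; within the scatter) and by a 1.7-fold higher number from compound 2 to compound 3 (0.22 log units; within the scatter). Only a 2.8-fold lower number from compound 1 to compound 2 (0.45 log units; beyond the scatter) goes beyond the scatter, and that step is modest.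

Compound 4 `Nc1c(-c2nc3ccccc3[nH]2)cc(-c2ccccc2)n1-c1ccc(Cl)cc1` keeps the 4-chlorophenyl group of compound 3 and changes another place on the core: 1H-benzimidazol-2-yl in place of cyano on an aromatic carbon. The new group stands on an aromatic carbon, next to the ring atom that bears an amino group. None of the three measured steps touches this place. They show how little this assay has moved so far, but they give no direct evidence on the direction of this replacement. A modest step toward a lower number is expected, though with low confidence and a wide margin. The estimated change is a 2.6-fold lower number from compound 3 to compound 4 (0.41 log units; beyond the scatter). For compound 4 the estimated value is 3000 nM, with an expected range of 700 nM to 14000 nM.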

Compound 4, half-maximal inhibitory concentration: 9900 nM
Beside the measured number, compound 4's estimate is 3.3-fold (0.52 log units) below it; the measured number falls inside the stated range.
By their numbers in this assay, from the lowest: compounds 2, 3, 4 and 1 (each within the scatter of the next, the first and the last beyond it).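

In this assay, 1H-benzimidazol-2-yl in place of cyano gives a 1.3-fold higher number from compound 3 to compound 4 (0.11 log units; within the scatter), so this change on the aromatic carbon next to the ring atom that bears an amino group leaves the number within the usual scatter. The earlier compounds shown here varied only the halogen-bearing phenyl group on the ring nitrogen, whereas this step shows that the position can carry one five-membered and one six-membered aromatic ring, plus a hydrogen-bond donor that cyano lacks, without a change beyond the scatter in this cytotoxicity read-out, at least with the 4-chlorophenyl group in place. Nothing given here explains why such different groups give numbers within the scatter of each other.

The compounds shown leave open whether a carboxylic acid, a primary amide or an aminomethyl group at this position would move the number beyond the scatter, and whether a 1-methylbenzimidazol-2-yl group, which has no hydrogen on its ring nitrogen, would behave like 1H-benzimidazol-2-yl. From the compounds shown here alone, it also remains open whether the same replacement would give a similar step with the 4-bromophenyl or 3-bromophenyl group on the ring nitrogen.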